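Swapping the ether aryl on the most potent urea

A few compounds are considered here, and "the series" means these few. Any claim that something is new, unique, unknown or untested is made for them only; others in the source may bear on it.

Measured so far:
compound 1 `O=C(Nc1ccc(I)cc1)N[C@H]1CC[C@H](Oc2ccc(F)cc2)CC1` gives 10200 nM in a functional assay on CRL2813 cells (Homo sapiens) for cytotoxicity, read by sulforhodamine B assay, with a stated time of 5 days; a lower number here means a stronger inhibitor, a higher number a weaker inhibitor
compound 2 `O=C(Nc1cccc(C(F)(F)F)c1)N[C@H]1CC[C@H](Oc2ccc(C(F)(F)F)cc2)CC1` gives 460 nM in this assay
compound 3 `Cc1cccc(NC(=O)N[C@H]2CC[C@H](Oc3ccc(F)cc3)CC2)c1` gives 14400 nM in this assay

Compound 2 stands lowest of the three numbers, beyond the scatter against both others. Compound 4 `O=C(Nc1cccc(C(F)(F)F)c1)N[C@H]1CC[C@H](Oc2ccccc2F)CC1` keeps its urea side and changes the ether side: 2-fluorophenyl in place of 4-(trifluoromethyl)phenyl on an oxygen on a saturated carbon. For the measured compounds named here, only one measured step is available, a 1.4-fold higher number from compound 1 to compound 3 (0.15 log units; within the scatter), and it concerns the urea-side aryl, not the ether-side aryl, so it does not bear on this change. Compounds 1 and 3 each differ from compound 2 in two places, so their values cannot separate the two sides. Compound 4 is therefore estimated at 2000 nM, within 500 nM to 8000 nM, a step expected as a 4.3-fold higher number from compound 2 to compound 4 (0.64 log units; beyond the scatter) toward a weaker inhibitor.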

Compound 4, half-maximal inhibitory concentration: 2450 nM
Compound 4: the middle estimate sits 1.2-fold (0.09 log units) below what was measured; measured number inside the range.
By their numbers in this assay, from the lowest: compound 2; then compound 4; then compounds 1 and 3 (each within the scatter of the next).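

With the urea side held fixed, the ether side alone moves the number in this assay: 2-fluorophenyl in place of 4-(trifluoromethyl)phenyl gives a 5.3-fold higher number from compound 2 to compound 4 (0.73 log units; beyond the scatter), toward a weaker inhibitor. For the compounds shown here, this is the first single-place change on the ether side, since the earlier step concerned only the urea-side aryl and stayed within the scatter. Nothing measured here explains the loss. The group and its place on the ring change together, so this single step cannot separate the two. Going by these compounds, how a plain phenyl, a methoxyphenyl or an aminophenyl would fare on this oxygen remains open.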